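The source may hold more compounds than are shown below. What is called first, only, known or untested is meant among the compounds shown, and "the series" means these compounds.

Measured so far in a functional assay on HCT-116 cells (Homo sapiens), read by MTT assay, with a stated time of 72 h; on this read-out higher numbers stand for weaker inhibition and lower numbers for stronger inhibition
compound 1 `COc1ncnc2c1c(-c1cc3ccccc3o1)cn2[C@@H]1O[C@H](CO)[C@@H](O)[C@H]1O` gives 14500 nM
compound 2 `CNc1ncnc2c1c(-c1cccs1)cn2[C@@H]1O[C@H](CO)[C@@H](O)[C@H]1O` gives > 20000 nM, a limit
compound 3 `CNc1ncnc2c1c(-c1ccccc1)cn2[C@@H]1O[C@H](CO)[C@@H](O)[C@H]1O` gives > 100000 nM, a limit

Compound 3 is known only through (the limit of > 100000 nM in this assay, at which 1 of the 3 values shown sits). Compound 2 is likewise known only through (the limit of > 20000 nM in this assay, at which 1 of the 3 values shown sits). Among the compounds with values here, the one measured step, a step that the two limits leave unreadable from compound 2 to compound 3, therefore gives no size to carry over.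

Compound 4 `CNc1ncnc2c1c(-c1cc3ccccc3o1)cn2[C@@H]1O[C@H](CO)[C@@H](O)[C@H]1O` differs from compound 3 as follows: 1-benzofuran-2-yl in place of phenyl on an aromatic carbon. The expectation rests on compound 1 with 14500 nM, which also carries 1-benzofuran-2-yl. The expected change is an at least 5.5-fold lower number from compound 3 to compound 4 (0.74 log units; beyond the scatter), an estimated move towards stronger inhibition in this assay. For compound 4 the estimated value is 18000 nM, with an expected range from 5000 nM to 80000 nM.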

Compound 4, half-maximal inhibitory concentration: > 20000 nM
Compound 4: no number, only a limit; the forecaster's own chance of this, stated with the estimate: 45%; at least 1.1-fold (0.04 log units) between middle value and limit.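

In this assay the 1-benzofuran-2-yl group with methylamino on the shared core yields no number, and compound 4 is a limit: the limit of > 20000 nM in this assay, at which 2 of the 4 values shown sit. Methylamino in place of methoxy on an aromatic carbon gives an at least 1.3-fold higher number from compound 1 to compound 4 (0.13 log units; that floor lies within the scatter), so this swap has no size beyond the scatter so far. The steps to compound 4 from compound 2 and from compound 3 cannot be read, as all three are limits.

Going by these compounds, how far compound 4 lies past its limit stays open, and with it whether methoxy truly outperforms methylamino. Also open, on these data alone, is what a plain amine or an ethoxy group at that carbon would give alongside 1-benzofuran-2-yl.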